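A Halogen Exchange on Compound 2

The source may hold more compounds than are shown below. What is called first, only, known or untested is meant among the compounds shown, and "the series" means these compounds.

In a functional assay on KG-1 cells (Homo sapiens) for cytotoxicity, read by luminescence and CellTiter-Glo, with a stated time of 3 days (a lower number here means a stronger inhibitor, a higher number a weaker inhibitor), compound 1 `N#Cc1ccc(NC(=O)c2cc(Cl)ccc2O)cc1` gives 1860 nM. Compound 2 `N#Cc1ccc(NC(=O)c2cc(Br)c(-c3ccccc3)cc2O)cc1` gives 850 nM, the lower of the two numbers, and the gap between them lies beyond the scatter. Compound 3 `N#Cc1ccc(NC(=O)c2cc(Cl)c(-c3ccccc3)cc2O)cc1` departs from compound 2 at one place: chloro in place of bromo on an aromatic carbon. The exchanged halogen sits ortho to a phenyl group and para to a hydroxy group. For the measured compounds named here, no measured pair isolates this exchange. In this assay, no change beyond the scatter is expected, and the estimated step is a 1.1-fold higher number from compound 2 to compound 3 (0.05 log units; within the scatter). Compound 3 is expected at 950 nM, within a range of 450 nM to 2000 nM.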

Compound 3, half-maximal inhibitory concentration: 480 nM
Beside the measured number, compound 3's estimate is 2.0-fold (0.30 log units) above it; the measured number falls inside the stated range.
By their numbers in this assay, from the lowest: compounds 3 and 2 (each within the scatter of the next); then compound 1.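

In this assay, chloro in place of bromo on this aromatic carbon, ortho to a phenyl group and para to a hydroxy group, gives a 1.8-fold lower number from compound 2 to compound 3 (0.25 log units; within the scatter), so the two halogens are not told apart here. For the compounds shown here, compound 3 also gives the first single-place reading of the phenyl group: phenyl in place of hydrogen gives a 3.9-fold lower number from compound 1 to compound 3 (0.59 log units; beyond the scatter). No evidence on the cause of either step is available. The compounds shown leave open whether a fluoro, a methyl or an amine on this aromatic carbon would read like chloro and bromo. Also open, on these data alone, is how a carboxylic acid on the phenyl group would read.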